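The source may report more compounds than this note shows. Statements on the series, on what has been measured and on what is new or still open speak of the compounds shown alone.

Compound 1 `COc1cccc(N2CCN(CC#CCOC(=O)c3sc4ncnc(N5CCCCC5)c4c3C)CC2)c1`: 40.4 ug/mL
Compound 2 `Cc1c(-c2nnc(-c3ccccc3)o2)sc2ncnc(N3CCCCC3)c12`: 22.1 ug/mL
Compound 3 `Cc1ccc(-c2nnc(-c3sc4ncnc(N5CCCCC5)c4c3C)o2)cc1`: 28.2 ug/mL

In a functional assay on PC-12 cells (Rattus norvegicus) for cytotoxicity, read by MTT assay, with a stated time of 24 h (a higher number here means that more compound is needed for the effect, a lower number that less compound is needed), compound 3 gives 28.2 ug/mL and lies within the scatter of both compound 1 and compound 2, so these three cannot be ranked. Compound 4 `COc1ccc(-c2nnc(-c3sc4ncnc(N5CCCCC5)c4c3C)o2)cc1` changes one group of compound 3: methoxy in place of methyl on an aromatic carbon, para to a large group (methoxy in place of methyl on an aromatic carbon). Among the measured compounds shown here, the one measured step that bears on this is methyl in place of hydrogen on an aromatic carbon (a 1.3-fold higher number from compound 2 to compound 3 (0.11 log units; within the scatter)), which stays within the scatter. That gives no reason to expect a step beyond the scatter here, and the expected step is small (a 1.0-fold lower number from compound 3 to compound 4 (0.02 log units; within the scatter)). For compound 4 the estimated value is 27 ug/mL (expected range 15 ug/mL to 46 ug/mL).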

Compound 4, half-maximal effective concentration: 20.1 ug/mL
Estimate against measurement, compound 4: 1.3-fold (0.13 log units) above, within the range that was stated.
By their numbers in this assay, from the lowest: compounds 4, 2, 3 and 1 (each within the scatter of the next).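

In this assay the change from 4-methylphenyl to 4-methoxyphenyl gives a 1.4-fold lower number from compound 3 to compound 4 (0.15 log units; within the scatter) and methoxy in place of hydrogen on the same aromatic carbon gives a 1.1-fold lower number from compound 2 to compound 4 (0.04 log units; within the scatter). This position has now carried hydrogen, methyl and methoxy, and every step among them stays within the scatter, even with the oxygen that methoxy brings. Nothing measured here offers an explanation for this. Still open, going by these compounds, is whether an amine or a carboxylic acid at this position would produce a step beyond the scatter.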